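A Small Change at the Thiocarbonyl End

The source may hold more compounds than are shown below. What is called first, only, known or untested is meant among the compounds shown, and "the series" means these compounds.

Of the compounds shown here, two have so far been tested in an ADME assay on KB cells (Homo sapiens) for cytotoxicity, read by MTT assay, with a stated time of 44 h; a higher number here means a weaker inhibitor, a lower number a stronger inhibitor. Compound 1 `Fc1cccc(F)c1NC(=S)N/N=C\c1c[nH]c2ccccc12` gives > 100000 nM in this assay, and this is a limit of the assay rather than a measured number. Compound 2 `CCN(CC)C(=S)N/N=C\c1c[nH]c2ccccc12` likewise reaches only the limit of this assay, giving > 100000 nM. Going by the values given here, compound 2 therefore stands at the limit, and the one other value shown sits at the same point (the limit of > 100000 nM in this assay, at which 2 of the 2 values shown sit). Compound 3 `CCCCN(C)C(=S)N/N=C\c1c[nH]c2ccccc12` differs from compound 2 in a single place: butyl(methyl)amino in place of diethylamino on a thiocarbonyl carbon. Among the compounds with values here, since no step between two measured compounds exists here, there is nothing to scale the change against, and the step from compound 2 to compound 3 is expected to be a number no higher from compound 2 to compound 3 (the limit leaves the size open), nothing beyond the scatter. Compound 3 is accordingly expected to give about 100000 nM in this assay, somewhere between 50000 nM and 300000 nM, most probably reported once more as a limit only.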

Compound 3, half-maximal inhibitory concentration: > 100000 nM
Compound 3 was reported as a limit; the forecaster's own chance of this, stated with the estimate: 80%; the middle value lies on the limit itself.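

Going by these compounds alone, compound 2 and compound 3 each reach only a limit, so no step between them can be read: the limit of > 100000 nM in this assay, at which 3 of the 3 values shown sit.

The compounds shown leave open whether any other group on the thiocarbonyl carbon would give a readable value in this assay.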